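The source may report more compounds than this note shows. Statements on the series, on what has been measured and on what is new or still open speak of the compounds shown alone.

Measured in a functional assay on SK-MEL-28 cells (Homo sapiens) for cytotoxicity, read by MTT assay, with a stated time of 3 days; a higher number here means a weaker inhibitor, a lower number a stronger inhibitor:
- compound 1 `N#Cc1c(-c2ccccc2)nc(SCc2nc3ccccc3[nH]2)nc1N1CCNCC1`: 2.6 nM
- compound 2 `Cc1ccc(S(=O)(=O)N2CCN(c3nc(SCc4nc5ccccc5[nH]4)nc(-c4ccccc4)c3C#N)CC2)cc1`: 4.38 nM

Compound 2, at 4.38 nM, lies within the scatter of compound 1. Compound 3 `N#Cc1c(-c2ccccc2)nc(SCc2nc3ccccc3[nH]2)nc1N1CCN(S(=O)(=O)c2ccccc2[N+](=O)[O-])CC1` carries 2-nitrophenyl in place of 4-methylphenyl on a sulfonyl sulfur. Within the data shown here, only one measured step bears on this change: a 1.7-fold higher number from compound 1 to compound 2 (0.23 log units; within the scatter). That step added the whole (4-methylphenyl)sulfonyl group in place of hydrogen and stayed within the scatter. With this single step as a guide, no change beyond the scatter is expected in this assay. The expected step is a 1.1-fold higher number from compound 2 to compound 3 (0.06 log units; within the scatter). The estimate for compound 3 is 5 nM, within an expected range of 1.7 nM to 15 nM.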

Compound 3, half-maximal inhibitory concentration: 8.9 nM
Compound 3: middle estimate off by 1.8-fold (0.25 log units), on the low side, within the range that was stated.
By their numbers in this assay, from the lowest: compounds 1 and 2 (each within the scatter of the next); then compound 3.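

In this assay the group on the sulfonyl sulfur can shift the number: replacing 4-methylphenyl with 2-nitrophenyl gives a 2.0-fold higher number from compound 2 to compound 3 (0.31 log units; beyond the scatter) and so goes beyond the scatter, which the addition of (4-methylphenyl)sulfonyl did not. Set against the hydrogen on the ring nitrogen, (2-nitrophenyl)sulfonyl gives a 3.4-fold higher number from compound 1 to compound 3 (0.53 log units; beyond the scatter) and remains a modest change. No supporting data explain this shift. Still open, as far as these compounds go, is how this assay would read with a longer alkyl chain or a carboxylic acid-bearing phenyl on the sulfonyl sulfur.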